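A few compounds are considered here, and "the series" means these few. Any claim that something is new, unique, unknown or untested is made for them only; others in the source may bear on it.

Going by the values given here, in a functional assay on Bel7402/5-FU cells (Homo sapiens) for antiproliferative activity, read by MTT assay, with a stated time of 72 h (on this read-out higher numbers stand for weaker inhibition and lower numbers for stronger inhibition), two compounds sharing one core have numbers so far. Compound 1 (`C=C1C(=O)O[C@H]2[C@H]1CC/C(COC(=O)Cn1cc(F)c(=O)n(Cc3ccc([N+](=O)[O-])cc3)c1=O)=C\CC[C@@]1(C)O[C@@H]21`), with 4-nitrophenyl on a saturated chain carbon bound to an aromatic nitrogen, gives 4340 nM on this read-out, and compound 2 (`C=C1C(=O)O[C@H]2[C@H]1CC/C(COC(=O)Cn1cc(F)c(=O)n(Cc3cccc(F)c3)c1=O)=C\CC[C@@]1(C)O[C@@H]21`), with 3-fluorophenyl in its place, gives 3700 nM on the same read-out. Compound 2 therefore stands within the scatter of compound 1, and neither ranks ahead of the other.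

Compound 3 (`C=C1C(=O)O[C@H]2[C@H]1CC/C(COC(=O)Cn1cc(F)c(=O)n(Cc3ccc(F)c(F)c3)c1=O)=C\CC[C@@]1(C)O[C@@H]21`) keeps all of compound 2 but has fluoro in place of hydrogen on an aromatic carbon, ortho to a fluoro group and para to a large group, turning 3-fluorobenzyl into 3,4-difluorobenzyl (fluoro in place of hydrogen on an aromatic carbon). Among the compounds with values here, no measured step tests this change directly. Within the data shown here, the only step that touches this aromatic ring (a 1.2-fold lower number from compound 1 to compound 2 (0.07 log units; within the scatter)) is a different exchange, and it stayed within the scatter. It offers no reason to expect a real shift, so the expected step (a 1.1-fold lower number from compound 2 to compound 3 (0.02 log units; within the scatter)) has no set direction and lies within the scatter. For compound 3 the estimate is 3500 nM in this assay, with an expected range from 1700 nM to 7500 nM around it.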

Compound 3, half-maximal inhibitory concentration: 4480 nM
Compound 3: the middle estimate sits 1.3-fold (0.11 log units) below what was measured; the measured number falls inside the stated range.
By their numbers in this assay, from the lowest: compounds 2, 1 and 3 (each within the scatter of the next).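

Compound 3 gives the direct reading of fluoro in place of hydrogen on the aromatic carbon ortho to a fluoro group and para to a large group, and in this assay the step (a 1.2-fold higher number from compound 2 to compound 3 (0.08 log units; within the scatter)) lies within the scatter, so 3-fluorophenyl and 3,4-difluorophenyl cannot be told apart here. The exchange of 4-nitrophenyl for 3,4-difluorophenyl (a 1.0-fold higher number from compound 1 to compound 3 (0.01 log units; within the scatter)) also lies within the scatter, which places all three aromatic groups shown within the scatter of one another on this read-out. No evidence is available that accounts for this result.

What remains open is whether any change on this aromatic ring can move the number beyond the scatter, as the three compounds shown do not settle that. As far as these compounds go, it is also open whether an amine or a carboxylic acid on the ring, or a longer chain joining the ring to the aromatic nitrogen, would give a number that stands apart from these three.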